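The source may hold more compounds than are shown below. What is called first, only, known or untested is meant among the compounds shown, and "the series" means these compounds.

Measured compounds in an ADME assay on L02 cells (Homo sapiens) for cytotoxicity, read by MTT assay, with a stated time of 48 h; on this read-out lower numbers stand for stronger inhibition and higher numbers for weaker inhibition:
compound 1 `CC(=O)OC[C@H]1CN(c2ccc(-n3cc(-c4ccccn4)cn3)c(F)c2)C(=O)O1` — > 400 ug/mL, a limit of the assay
compound 2 `CS(=O)(=O)NC[C@H]1CN(c2ccc(-n3cc(-c4ccccn4)cn3)c(F)c2)C(=O)O1` — > 400 ug/mL, a limit of the assay
compound 3 `NC(=O)[C@H]1CN(c2ccc(-n3cc(-c4ccccn4)cn3)c(F)c2)C(=O)O1` — 119 ug/mL

Compound 1 stands at the limit of > 400 ug/mL in this assay, at which 2 of the 3 values shown sit, so its own value is not a number. Compound 3 alone returns a number. Going by the values given here, the step of an at least 3.3-fold lower number from compound 1 to compound 3 (0.52 log units; beyond the scatter) is the one measured change that bears on the move to compound 4 `CONC(=O)[C@H]1CN(c2ccc(-n3cc(-c4ccccn4)cn3)c(F)c2)C(=O)O1`: it replaces the same acetoxymethyl group at the same ring carbon, and carbamoyl is the close relative of the entering methoxycarbamoyl. The change to compound 4 is methoxycarbamoyl in place of acetoxymethyl on a saturated ring carbon. The step of an at least 3.3-fold lower number from compound 2 to compound 3 (0.52 log units; beyond the scatter) points the same way, and a step that the two limits leave unreadable from compound 1 to compound 2 cannot be read. A lower number in this assay is therefore expected for compound 4, of at least modest size and in the direction of compound 3, roughly an at least 2.6-fold lower number from compound 1 to compound 4 (0.42 log units; beyond the scatter). The estimate for compound 4 in this assay is 150 ug/mL, within 60 ug/mL to 400 ug/mL.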

Compound 4, half-maximal inhibitory concentration: > 400 ug/mL
Compound 4 was reported as a limit (the forecaster's own chance of this, stated with the estimate: 35%); at least 2.6-fold (0.42 log units) between middle value and limit.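

In this assay, methoxy in place of hydrogen on an amide-type nitrogen gives an at least 3.3-fold higher number from compound 3 to compound 4 (0.52 log units; beyond the scatter). At this saturated ring carbon next to the ring oxygen, the lower number seen with carbamoyl in compound 3 therefore does not carry over to methoxycarbamoyl in compound 4, so a change on the amide-type nitrogen alone separates the two compounds. Compound 4 is a limit, not a number: the limit of > 400 ug/mL in this assay, at which 3 of the 4 values shown sit.

The steps to compound 4 from compound 1 and from compound 2 cannot be read, as both ends of each are limits. Also open, as far as these compounds go, is whether a methyl or longer alkyl chain on the amide-type nitrogen, or a carboxylic acid at this ring carbon, would return a number in this assay or stay at the limit.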